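From 4-bromophenyl to 4-aminophenyl: notes on compound 4

The compounds below may be only part of what the source reports. "The series", "measured", "known", "first", "only" and "open" are said of these compounds alone.

The series is read in a functional assay on SK-MEL cells (Homo sapiens) for cytotoxicity, read by MTT assay, with a stated time of 6 days; a lower number here means that less compound is needed, a higher number that more compound is needed for the effect. Compound 1 (`COC(=O)c1c(-c2cc(OC)cc(OC)c2)oc2ccccc2c1=O`) gives > 25 ug/mL, which is a limit and not a number. Compound 2 (`COC(=O)c1c(-c2ccc(Br)cc2)oc2ccccc2c1=O`) gives > 25 ug/mL, which is also a limit and not a number. Among the compounds with values here, compound 3 (`COC(=O)c1c(-c2ccc([N+](=O)[O-])cc2)oc2cc(OC)ccc2c1=O`) gives 2.84 ug/mL, the only actual number so far. Compound 2 thus stands at the limit of > 25 ug/mL in this assay, at which 2 of the 3 values shown sit.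

Compound 4 (`COC(=O)c1c(-c2ccc(N)cc2)oc2ccccc2c1=O`) has not yet been measured in this assay. It differs from compound 2 as follows: amino in place of bromo on an aromatic carbon. This places amino in place of bromo on an aromatic carbon, para to a large group, turning 4-bromophenyl into 4-aminophenyl.

Within the data shown here, no measured pair shows this change. A modest move towards a lower number is expected, and a reading at the limit remains quite possible. This expectation rests on compound 3 at 2.84 ug/mL, which shows that a number can be reached in the series. The estimated step is an at least 1.3-fold lower number from compound 2 to compound 4 (0.14 log units; that floor lies within the scatter). For compound 4 the expected value is 18 ug/mL, with an estimated range of 6 ug/mL to 40 ug/mL.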

Compound 4, concentration for half-maximal effect: > 25 ug/mL
Compound 4: only a limit was reported; the forecaster's own chance of this, stated with the estimate: 55%; middle value at least 1.3-fold (0.14 log units) away from the limit.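

Compound 2 and compound 4 are both reported only as limits and not as numbers, so the step between them cannot be read. The compounds shown leave open whether amino in place of bromo on an aromatic carbon changes the cytotoxicity reading at all, and in which direction.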